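Methyl in place of methoxy on compound 3

The compounds below may be only part of what the source reports. "The series", "measured", "known", "first", "only" and "open" are said of these compounds alone.

Compound 1 (`Cc1nc(N2CCN(C)CC2)c2nc(-c3ccccc3Cl)n(CCO)c2n1`) : (6%)
Compound 2 (`CCN1CCN(c2nc(C)nc3c2nc(-c2ccccc2Cl)n3CCOC)CC1`) : (53%)
Compound 3 (`COc1ccccc1-c1nc2c(N3CCN(C)CC3)nc(C)nc2n1C1CCOCC1`) : (35%)

These three compounds were measured in an ADME assay (liver) for metabolic stability, with Liver microsome (Rattus norvegicus) as the target, read by LC-MS, using microsomes, with a stated time of 30 min, tested at 4 uM (a higher number here means that more of the compound is left, a lower number that less of the compound is left), and together they span a wide stretch of that scale. Compound 3 holds the middle place of the three. Its number lies below that of compound 2 and above that of compound 1, and both gaps are beyond the usual scatter of repeated measurements.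

The next compound to be measured is compound 4 (`Cc1nc(N2CCN(C)CC2)c2nc(-c3ccccc3C)n(C3CCOCC3)c2n1`). It differs from compound 3 in one place, with methyl in place of methoxy on an aromatic carbon. The 2-methoxyphenyl of compound 3 thus becomes 2-methylphenyl.

Among the compounds with values here, no pair of measured compounds differs in only one place, so the data do not show what a single change of this kind does in this assay. The best available anchor is therefore compound 3 (35%), and no step beyond the scatter is expected. The expected step is small and slightly upward (a number 3 percentage points higher from compound 3 to compound 4 (within the scatter)), though the estimate is uncertain in either direction. For compound 4 the estimated value is (38%), with an expected range from (20%) to (58%).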

Compound 4, percent of the compound remaining: 39%
The estimate for compound 4 lay 1 percentage points below the measured number; low and high end bracket the measured number.
By their numbers in this assay, from the lowest: compound 1; then compounds 3 and 4 (each within the scatter of the next); then compound 2.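

In this assay, within the data shown here, the swap of 2-methoxyphenyl for 2-methylphenyl gives the first step in this set that can be read at a single place (a number 4 percentage points higher from compound 3 to compound 4 (within the scatter)). On this aromatic carbon, ortho to a large group, methoxy with its 2 heavy atoms and 1 hydrogen-bond acceptor and methyl with its 1 heavy atom and 0 hydrogen-bond acceptors therefore cannot be told apart by the percent of compound remaining, so the oxygen of the methoxy shows no effect on this read-out in this pair. Among these compounds, nothing measured here explains that outcome, and the pair shows only that this one swap, on the shared core of these two compounds, stays inside the usual scatter.

Compounds 1 and 2 carry a 2-chlorophenyl but also differ from compounds 3 and 4 elsewhere, so the compounds shown leave open how chlorine at this place would compare with methoxy or methyl when everything else stays the same. Also open, going by these compounds, is whether a quite different group on this ring, such as a fluorine, a nitrile or an amine, would stay as close to these two compounds.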